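Swapping methoxy for dimethylamino in a cytotoxicity series

This account rests on a few compounds, and the source may have more. Where it says the series, first, only, none or still open, it means among the compounds named here.

Of the compounds shown here, two with a shared core have been tested so far in a functional assay on HepG2 cells (Homo sapiens) for cytotoxicity, read by CCK-8 assay; a lower number here means a stronger inhibitor, a higher number a weaker inhibitor. Compound 1 (`COc1ccc(NC(=O)c2ncc(-c3cc(OC)c(OC)c(OC)c3)o2)cc1`) is recorded as > 30000 nM, a limit of the assay and not a number. Compound 2 (`COc1ccc(NC(=O)c2ncc(-c3ccccc3)o2)cc1`) is recorded as > 30000 nM, which is also a limit. Within the data shown here, compound 2 therefore has no number of its own, and the only other reading gives none either: both sit at the limit of > 30000 nM in this assay, at which 2 of the 2 values shown sit.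

The next compound, compound 3 (`CN(C)c1ccc(NC(=O)c2ncc(-c3ccccc3)o2)cc1`), has dimethylamino in place of methoxy on an aromatic carbon, para to a large group: dimethylamino in place of methoxy on an aromatic carbon. Among the measured compounds shown here, no measured step shows what such a swap does. In this assay, the expected step of a number no higher from compound 2 to compound 3 (the limit leaves the size open) is none beyond the scatter, with no direction favoured, and another limit is quite possible. For compound 3 the estimated value is 30000 nM, with an expected range of 8000 nM to 60000 nM.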

Compound 3, half-maximal inhibitory concentration: > 30000 nM
Compound 3 gave a limit, no number; the forecaster's own chance of this, stated with the estimate: 65%; the middle value sits exactly at the limit.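

Compound 2 and compound 3 both stand as limits in this assay, not numbers, so the step from methoxy to dimethylamino cannot be read. The compounds shown leave open whether any change on the shared core gives a readable number in this assay: the limit of > 30000 nM in this assay, at which 3 of the 3 values shown sit.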